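One Side Chain for Another: From Compound 2 to Compound 4

The source may report more compounds than this note shows. Statements on the series, on what has been measured and on what is new or still open speak of the compounds shown alone.

Compound 1 `Cc1noc(NS(=O)(=O)c2cccc([N+](=O)[O-])c2)c1C`: 7800 nM
Compound 2 `Cc1noc(NS(=O)(=O)c2cccc3c(CN(C)C)cccc23)c1C`: 2800 nM
Compound 3 `Cc1noc(NS(=O)(=O)c2cccc(-c3ccccc3)c2)c1C`: 5400 nM

Of the compounds shown here, three with a shared core have been tested in an assay on VSM-A10 cells for antagonist activity at Endothelin-1 receptor (Rattus norvegicus); a higher number here means a weaker inhibitor, a lower number a stronger inhibitor. Compound 1 gives 7800 nM, compound 3 gives 5400 nM and compound 2 gives 2800 nM. Compound 2 therefore carries the lowest of the three numbers, but its gap to compound 3 lies within the scatter, so the two cannot be ranked against each other; only the gap to compound 1 is beyond the scatter.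

For the measured compounds named here, the single step between compounds that differ in one place is a 1.4-fold lower number from compound 1 to compound 3 (0.16 log units; within the scatter), a change at a different spot of the core and of a different kind.

Compound 4 `Cc1noc(NS(=O)(=O)c2cccc3c(C(C)(C)O)cccc23)c1C` is the next compound to be measured in this assay . It differs from compound 2 in one way: 1-hydroxy-1-methylethyl in place of (dimethylamino)methyl on an aromatic carbon. Going by the values given here, none of the measured steps touches this group or this position, so nothing in the present numbers argues for a shift in either direction. The expected outcome is therefore a step of a 1.1-fold higher number from compound 2 to compound 4 (0.03 log units; within the scatter), meaning no change beyond the scatter. For compound 4 the estimated value in this assay is 3000 nM, with a range from 1000 nM to 9000 nM.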

Compound 4, half-maximal inhibitory concentration: 2890 nM
Estimate against measurement, compound 4: 1.0-fold (0.02 log units) above; low and high end bracket the measured number.
By their numbers in this assay, from the lowest: compounds 2, 4, 3 and 1 (each within the scatter of the next, the first and the last beyond it).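

In this assay, putting 1-hydroxy-1-methylethyl in place of (dimethylamino)methyl on this aromatic carbon gives a 1.0-fold higher number from compound 2 to compound 4 (0.01 log units; within the scatter), so compound 2 and compound 4 cannot be told apart. The exchange is not a small one on paper: the nitrogen of the old side chain gives way to an oxygen, and a side chain with no hydrogen-bond donor gives way to one with a hydrogen-bond donor, yet the reading stays within the scatter, which shows that for this pair the nitrogen is not needed to keep the number where it stands. No measurement is at hand that would explain why these two side chains read alike.

Both side chains have the same count of heavy atoms and neither contains a ring, so the compounds shown do not tell how much room for change this position allows. On these data alone, how a carboxylic acid, a longer chain ending in an amine, or a plain hydrogen on the same aromatic carbon would read remains open.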